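From diisopropylamino to pyrrolidin-1-yl: a clearance estimate

A few compounds are considered here, and "the series" means these few. Any claim that something is new, unique, unknown or untested is made for them only; others in the source may bear on it.

Within the data shown here, in an ADME assay (liver) for metabolic stability, with Liver microsome (Homo sapiens) as the target, using microsomes (a higher number here means faster removal of the compound, a lower number slower removal), compound 1 (`CC(C)N(C(=O)n1cnc(S[C@@H]2C[C@H]3CC[C@@H]2C3)n1)C(C)C`) gives 3.1 mL.min-1.g-1, the higher of the two numbers measured so far. Compound 2 (`O=C(N1CCCC1)n1cnc(S(=O)(=O)[C@@H]2C[C@H]3CC[C@@H]2C3)n1`), which also carries pyrrolidin-1-yl, gives 1 mL.min-1.g-1. Compound 3 (`O=C(N1CCCC1)n1cnc(S[C@@H]2C[C@H]3CC[C@@H]2C3)n1`) has pyrrolidin-1-yl in place of the diisopropylamino of compound 1 on a carbonyl carbon: pyrrolidin-1-yl in place of diisopropylamino on a carbonyl carbon. Among the measured compounds shown here, no measured pair shows this change alone, so any forecast for this assay is uncertain. No step beyond the scatter is expected, and the estimated change is a 1.6-fold lower number from compound 1 to compound 3 (0.19 log units; within the scatter). For compound 3 the expected value is 2 mL.min-1.g-1, with an estimated range of 1 mL.min-1.g-1 to 4 mL.min-1.g-1.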

Compound 3, intrinsic clearance in microsomes: 1.5 mL.min-1.g-1
For compound 3 the middle estimate is 1.3-fold (0.12 log units) above the measured one; the measured number falls inside the stated range.
By their numbers in this assay, from the lowest: compounds 2 and 3 (each within the scatter of the next); then compound 1.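

In this assay, among these compounds, pyrrolidin-1-yl in place of diisopropylamino on a carbonyl carbon gives a 2.1-fold lower number from compound 1 to compound 3 (0.32 log units; beyond the scatter) as the one change between two compounds. This shows that the number responds to the group at this position, although the step is modest. Nothing measured here explains the step. Still open, from the compounds shown here alone, is how diethylamino or piperidin-1-yl would behave at the same place. The two compounds also cannot separate the effect of having a ring from that of having fewer heavy atoms.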